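A few compounds are considered here, and "the series" means these few. Any claim that something is new, unique, unknown or untested is made for them only; others in the source may bear on it.

Compound 1 `C=C(Br)C(=O)Nc1cccc(-c2cn3nc(-c4ccc(C)cc4)sc3n2)c1` carries the 4-methylphenyl group on its core and in a functional assay on HeLa cells (Homo sapiens) for inhibition, read by cell counting, with a stated time of 4 days (a lower number here means a stronger inhibitor, a higher number a weaker inhibitor), compound 1 gives 2000 nM, the lowest of the three numbers recorded. Compound 3 `CCc1ccc(-c2nn3cc(-c4cccc(N)c4)nc3s2)cc1` gives 8100 nM in this assay, and compound 2 `Nc1cccc(-c2cn3c(-c4ccc(Cl)cc4)csc3n2)c1` gives 17000 nM in this assay; both gaps from compound 1 lie beyond the scatter, so compound 1 is the most potent of the three. For the measured compounds named here, compounds 2 and 3 each differ from compound 1 in more than one place, so no single step is recorded for any pair.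

Compound 4 `C=C(Br)C(=O)Nc1cccc(-c2cn3nc(Cc4ccc(Cl)cc4)sc3n2)c1` is not yet measured. It differs from compound 1 as follows: 4-chlorobenzyl in place of 4-methylphenyl on an aromatic carbon. Going by the values given here, no measured step isolates this exchange, so the direction is uncertain. A moderate weakening is expected, since every other variant so far, compound 2 at 17000 nM and compound 3 at 8100 nM, sits above compound 1. The expected step is a 2.0-fold higher number from compound 1 to compound 4 (0.30 log units; within the scatter). Compound 4 is therefore estimated at 4000 nM in this assay, within 1000 nM to 16000 nM.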

Compound 4, half-maximal inhibitory concentration: 2700 nM
Estimate against measurement, compound 4: 1.5-fold (0.17 log units) above; measured number inside the range.
By their numbers in this assay, from the lowest: compounds 1 and 4 (each within the scatter of the next); then compound 3; then compound 2.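

In this assay, for the compounds shown here, 4-chlorobenzyl in place of 4-methylphenyl on the aromatic carbon next to the ring sulfur gives a 1.4-fold higher number from compound 1 to compound 4 (0.13 log units; within the scatter), the only step so far that isolates one place. This position therefore accepts a benzyl group as well as a directly attached phenyl ring, with the rest of the structure unchanged and no change in the number beyond the scatter. No measurement on hand explains this result.

This single step combines two changes, the added carbon link and chlorine for methyl, so their separate contributions and any offset between them remain unresolved. Also open, from the compounds shown here alone, is how an amine, a carboxylic acid or a longer chain on this carbon would read in this assay.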